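The compounds below may be only part of what the source reports. "The series", "measured", "known", "first", "only" and "open" are said of these compounds alone.

Compound 1, `Cc1ccc(NC(=O)c2c(NO)cc(-c3ccccc3)oc2=O)cc1`, in an ADME assay on Huh-7 cells (Homo sapiens) for cytotoxicity, read by a luciferase reporter and WST assay, with a stated time of 3 days; a higher number here means that more compound is tolerated, a lower number that less compound is tolerated: > 20000 nM
Compound 2, `Cc1ccc(NC(=O)c2c(NO)cc(-c3ccc(F)cc3)oc2=O)cc1`, in this assay: > 20000 nM
Compound 3, `CNC(=O)c1c(NO)cc(-c2ccccc2)oc1=O`, in this assay: > 20000 nM

The value of compound 1 in this assay is a limit of the assay and not a number. The value of compound 2 in this assay is likewise a limit. The value of compound 3 in this assay is also a limit. All three sit at the limit of > 20000 nM in this assay, at which 3 of the 3 values shown sit.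

Going from compound 1 to compound 2, the change is fluoro in place of hydrogen on an aromatic carbon, and the step in this assay is a step that the two limits leave unreadable from compound 1 to compound 2. Going from compound 1 to compound 3, the two cores differ by methyl in place of 4-methylphenyl on an amide-type nitrogen, and the step in this assay is a step that the two limits leave unreadable from compound 1 to compound 3.

Compound 4, `CNC(=O)c1c(NO)cc(-c2ccc(F)cc2)oc1=O`, has not yet been measured in this assay. It differs from compound 3 by fluoro in place of hydrogen on an aromatic carbon, the same kind of change as that from compound 1 to compound 2, with the same words describing its place. Since that earlier step could not be read because both ends of it stand at the limit of > 20000 nM in this assay, at which 3 of the 3 values shown sit, the step from compound 3 to compound 4 is expected to be a step that the limit leaves unreadable from compound 3 to compound 4, most likely again ending at a limit. Compound 4 is therefore estimated in this assay at 30000 nM, within 15000 nM to 100000 nM.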

Compound 4, half-maximal cytotoxic concentration: > 20000 nM
Compound 4: no number, only a limit (the forecaster's own chance of this, stated with the estimate: 85%); the middle value lies beyond the limit too.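

In this assay compound 4 gives > 20000 nM, which is a limit and not a number. No new step can be read, neither from compound 3 to compound 4 nor from compound 2 to compound 4. The compounds shown leave open how the four compare with one another, and whether either change makes any difference in tolerated concentration, since all stand at one value: the limit of > 20000 nM in this assay, at which 4 of the 4 values shown sit.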